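From 1-methylcyclopropyl to 2-methylcyclopropyl on a carbonyl carbon

The source may hold more compounds than are shown below. What is called first, only, known or untested is meant among the compounds shown, and "the series" means these compounds.

In an ADME assay on microsomes from liver (Rattus norvegicus) for pharmacokinetics (on this read-out higher numbers stand for fast clearance and lower numbers for slow clearance), compound 1 (`Cn1cc(-c2ncc(C#N)c(N3C[C@@H]4C[C@H]3CN4S(=O)(=O)C3CC3)n2)cn1`) gives < 36 mL/min/kg as a limit of the assay and not a number. Compound 2 (`C[C@@H]1CN(c2nc(-c3cnn(C)c3)ncc2C#N)CCN1C(=O)C1(C)CC1`) also gives < 36 mL/min/kg as a limit and not a number. It therefore stands with the set on the limit of < 36 mL/min/kg in this assay, at which 2 of the 3 values shown sit, and has no exact value of its own. Among the measured compounds shown here, compound 3 (`C[C@@H]1CN(c2nc(-c3cnn(C)c3)cnc2C#N)CCN1C(=O)C1CC1`) gives 39 mL/min/kg and is the only exact number available in this assay here.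

Compound 4 (`CC1CC1C(=O)N1CCN(c2nc(-c3cnn(C)c3)ncc2C#N)C[C@H]1C`) differs from compound 2 by one change (2-methylcyclopropyl in place of 1-methylcyclopropyl on a carbonyl carbon) with 2-methylcyclopropyl in place of 1-methylcyclopropyl on a carbonyl carbon. For the measured compounds named here, no measured pair shows what such a change does, so no step beyond the scatter is expected, in either direction. The expected result is a step that the limit leaves unreadable from compound 2 to compound 4 and this is taken as a step within the usual scatter. For compound 4 the estimated clearance is 35 mL/min/kg with an expected range from 20 mL/min/kg to 65 mL/min/kg in this assay once it is measured.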

Compound 4, clearance: < 36 mL/min/kg
Compound 4 ended at the assay's limit; the forecaster's own chance of this, stated with the estimate: 55%; the middle value does not contradict the limit.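

Compound 2 and compound 4 both sit at a limit of the assay and not at a number, so no step can be read between them: the limit of < 36 mL/min/kg in this assay, at which 3 of the 4 values shown sit. The compounds shown leave open whether 2-methylcyclopropyl and 1-methylcyclopropyl differ at all in this assay once exact values are available.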